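This account rests on a few compounds, and the source may have more. Where it says the series, first, only, none or still open, it means among the compounds named here.

Working notes on the series. Compound 1 `O=C(/C=C\Nc1ccc(F)cc1)c1cn(-c2ccccc2)nc1-c1ccc(F)cc1` gives 18200 nM in a functional assay on U-87MG ATCC cells (Homo sapiens) for antiproliferative activity, read by MTT assay, with a stated time of 48 h; a lower number here means a stronger inhibitor, a higher number a weaker inhibitor. Compound 3 `O=C(/C=C\Nc1ccc(F)cc1)c1cn(-c2ccccc2)nc1-c1ccc(Cl)cc1` gives 17900 nM in this assay. Compound 2 `O=C(/C=C\Nc1ccc(C(F)(F)F)cc1)c1cn(-c2ccccc2)nc1-c1ccc(F)cc1` reaches only the limit of this assay, > 50000 nM. Of the two numbers shown, compound 3 and compound 1 sit together within the scatter of each other, a 1.0-fold lower number from compound 1 to compound 3 (0.01 log units; within the scatter), so no order between them can be read. The third value shown is the limit (the limit of > 50000 nM in this assay, at which 1 of the 3 values shown sits).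

Compound 4 `O=C(/C=C\Nc1ccc(C(F)(F)F)cc1)c1cn(-c2ccccc2)nc1-c1ccc(Cl)cc1` differs from compound 3 by trifluoromethyl in place of fluoro on an aromatic carbon. Within the data shown here, the one measured step with the same change is an at least 2.7-fold higher number from compound 1 to compound 2 (0.43 log units; beyond the scatter), which ran into the limit of this assay rather than ending at a number. On that basis an upward step of at least similar size is expected for the present pair, estimated as a 3.1-fold higher number from compound 3 to compound 4 (0.49 log units; beyond the scatter). Compound 4 is therefore expected to give about 55000 nM, with a range from 25000 nM to 150000 nM, and this assay may again report only a limit for compound 4.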

Compound 4, half-maximal inhibitory concentration: > 50000 nM
Compound 4: no number, only a limit; the forecaster's own chance of this, stated with the estimate: 70%; the middle value lies beyond the limit too.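

The higher number that trifluoromethyl in place of fluoro gave on the core of compound 1 is not confined to that core, since the change gives an at least 2.7-fold higher number from compound 3 to compound 4 (0.44 log units; beyond the scatter) on the core of compound 3, with chloro on the other ring: the same change on two cores in this assay, an at least 2.7-fold higher number (0.43 log units; beyond the scatter) from compound 1 to compound 2 and an at least 2.7-fold higher number (0.44 log units; beyond the scatter) from compound 3 to compound 4; the limit leaves it open whether they differ Both ends of the step from compound 2 to compound 4 are limits, so the effect of chloro in place of fluoro cannot be read with trifluoromethyl present. The upper end of the readable range now constrains this part of the series: the limit of > 50000 nM in this assay, at which 2 of the 4 values shown sit.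

As far as these compounds go, how far compound 2 and compound 4 lie beyond the limit remains open. Also open, from the compounds shown here alone, is whether a methoxy group, a dimethylamino group or a carboxylic acid at this position would give a number that differs from compound 3 at 17900 nM in this assay.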